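The source may report more compounds than this note shows. Statements on the series, on what has been measured and on what is new or still open speak of the compounds shown alone.

In a functional assay on NCI-H69 cells (Homo sapiens) for cytotoxicity, read by MTT assay, with a stated time of 3 days (on this read-out lower numbers stand for stronger inhibition and higher numbers for weaker inhibition), compound 1 (`CCCCCOC(=O)Nc1nc(=O)n([C@@H]2O[C@H](C)[C@H]3OC(=O)O[C@H]32)cc1F`) gives 180 ug/mL and compound 2 (`CCC(C)COC(=O)Nc1nc(=O)n([C@@H]2O[C@H](C)[C@H]3OC(=O)O[C@H]32)cc1F`) gives 330 ug/mL. These two values lie within the usual scatter of repeated measurements, so the numbers do not separate compound 2 from compound 1. Compound 3 (`CC(C)CCOC(=O)Nc1nc(=O)n([C@@H]2O[C@H](C)[C@H]3OC(=O)O[C@H]32)cc1F`) has not yet been measured. It has the same atoms as compound 2, joined differently: isobutyl in place of sec-butyl on a saturated chain carbon bound to an oxygen next to a carbonyl group. Cut one bond further out, this reads 2-methylbutyl to isopentyl. Going by the values given here, the one measured step that bears on this is a similar rearrangement at the same place, sec-butyl in place of butyl, and it is a 1.8-fold higher number from compound 1 to compound 2 (0.26 log units; within the scatter). Among the compounds with values here, with only that small step as a guide, no change beyond the scatter is expected in this assay, and the estimated step is a 1.3-fold lower number from compound 2 to compound 3 (0.12 log units; within the scatter). Compound 3 is expected to give about 250 ug/mL, with an estimated range of 120 ug/mL to 500 ug/mL.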

Compound 3, half-maximal inhibitory concentration: 310 ug/mL
Estimate against measurement, compound 3: 1.2-fold (0.09 log units) below; low and high end bracket the measured number.
By their numbers in this assay, from the lowest: compounds 1, 3 and 2 (each within the scatter of the next).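

In this assay, moving the branch from sec-butyl to isobutyl, on a saturated chain carbon bound to an oxygen next to a carbonyl group, gives a 1.1-fold lower number from compound 2 to compound 3 (0.03 log units; within the scatter). The other new comparison, with the unbranched chain of compound 1, is a 1.7-fold higher number from compound 1 to compound 3 (0.24 log units; within the scatter), so among these three compounds neither the presence of a branch nor its place on the chain separates one compound from another. No measured information is available to explain these numbers.

From the compounds shown here alone, all three compounds carry saturated hydrocarbon chains, so it remains open whether a much shorter ethyl chain, a longer octyl chain, or a chain ending in an amine or a carboxylic acid would shift the number beyond the scatter. Going by these compounds, it also remains open whether a ring such as benzyl at this place would do so.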